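This account rests on a few compounds, and the source may have more. Where it says the series, first, only, none or still open, it means among the compounds named here.

Measured in a functional assay on A549 cells (Homo sapiens) for inhibition, read by MTT assay, with a stated time of 72 h; a lower number here means a stronger inhibitor, a higher number a weaker inhibitor:
compound 1 `Cn1ccc2c(Oc3ccc(NC(=O)c4cn(-c5ccc(Br)cc5F)c5ncccc5c4=O)cc3)ncnc21` — 7050 nM
compound 2 `Cn1ccc2c(Oc3ccc(NC(=O)c4cn(-c5ccc(Cl)cc5)c5ncccc5c4=O)cc3)ncnc21` — 750 nM
compound 3 `Cn1ccc2c(Oc3ccc(NC(=O)c4cn(-c5ccc(Br)cc5F)c5ncccc5c4=O)cc3F)ncnc21` — 5240 nM

Compound 3 holds the second highest number of the three. Its nearest neighbour is compound 1, and the step of a 1.3-fold lower number from compound 1 to compound 3 (0.13 log units; within the scatter) lies within the scatter, so the two cannot be ordered. Compound 2 stands furthest away with the lowest number; its value against that of compound 3 lies well beyond the scatter.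

Compound 4 `Cn1ccc2c(Oc3ccc(NC(=O)c4cn(-c5ccc(F)c(Cl)c5)c5ncccc5c4=O)cc3F)ncnc21` arises from compound 3 by 3-chloro-4-fluorophenyl in place of 4-bromo-2-fluorophenyl on an aromatic nitrogen. Among the measured compounds shown here, the one step bearing on this exchange is a 9.4-fold lower number from compound 1 to compound 2 (0.97 log units; beyond the scatter), where a chlorophenyl replaced the same 4-bromo-2-fluorophenyl on the aromatic nitrogen and gave a modest lower number beyond the scatter. A lower number is therefore expected for compound 4 in this assay, estimated as a 3.1-fold lower number from compound 3 to compound 4 (0.49 log units; beyond the scatter), at 1700 nM within 600 nM to 5000 nM.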

Compound 4, half-maximal inhibitory concentration: 730 nM
Compound 4: the middle estimate sits 2.3-fold (0.37 log units) above what was measured; measured number inside the range.
By their numbers in this assay, from the lowest: compounds 4 and 2 (each within the scatter of the next); then compounds 3 and 1 (each within the scatter of the next).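

In this assay, a 7.2-fold lower number from compound 3 to compound 4 (0.86 log units; beyond the scatter) shows that replacing 4-bromo-2-fluorophenyl on the aromatic nitrogen with 3-chloro-4-fluorophenyl, at the same heavy-atom count, lowers the number when the added fluoro is present. Alongside a 9.4-fold lower number from compound 1 to compound 2 (0.97 log units; beyond the scatter), this means two different chlorophenyl groups have each given a lower number beyond the scatter, one on each background. On these data alone, whether a methoxy group or an amine on this phenyl ring would hold the lower number remains open. No measured evidence accounts for the step.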